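One methyl step, two cores: estimate for compound 4

This account rests on a few compounds, and the source may have more. Where it says the series, first, only, none or still open, it means among the compounds named here.

Measured so far in a functional assay on A549 cells (Homo sapiens) for antiproliferative activity, read by MTT assay, with a stated time of 48 h; a lower number here means a stronger inhibitor of growth, a higher number a weaker inhibitor of growth:
compound 1 `COc1ccc(/C=C2\Cc3c(cc(OC)c(OC)c3OC)C2=O)cc1O` gives 249 nM
compound 2 `COc1ccc(/C=C2\Cc3c(cc(OC)c(OC)c3OC)C2=O)cc1OC` gives 9740 nM
compound 3 `COc1cc2c(cc1O)C(=O)/C(=C/c1cc(OC)c(OC)c(OC)c1)C2` gives only a limit, > 10000 nM

Compound 1 and compound 2 share one core and differ by methyl in place of hydrogen on an oxygen on an aromatic ring. In this assay that change produces a 39-fold higher number from compound 1 to compound 2 (1.59 log units; beyond the scatter). Compound 3 has the same atoms as compound 1 joined differently; the difference between the two cores is not broken down here. For compound 3 the result in this assay is a limit and not a number, > 10000 nM. This is the limit of > 10000 nM in this assay, at which 1 of the 3 values shown sits.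

Compound 4 `COc1cc2c(cc1OC)C(=O)/C(=C/c1cc(OC)c(OC)c(OC)c1)C2` is still to be measured in this assay. It differs from compound 3 by methyl in place of hydrogen on an oxygen on an aromatic ring, which is the same change as that from compound 1 to compound 2, at the same kind of place. Among the compounds with values here, the one measured instance of this change moved the number upward, beyond the scatter, as a 39-fold higher number from compound 1 to compound 2 (1.59 log units; beyond the scatter) shows. The starting point for compound 3 is already a limit, > 10000 nM. The step from compound 3 to compound 4 is therefore expected to be a step that the limit leaves unreadable from compound 3 to compound 4, in the same direction. Compound 4 is expected to sit near 40000 nM, most likely between 10000 nM and 300000 nM, and is expected to be reported again as a limit rather than as a number.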

Compound 4, concentration for 50% growth inhibition: > 10000 nM
Compound 4: a limit, no number (the forecaster's own chance of this, stated with the estimate: 90%); the middle value lies beyond the limit too.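

In this assay compound 3 and compound 4 both give a limit and not a number, so the step between them cannot be read: the limit of > 10000 nM in this assay, at which 2 of the 4 values shown sit.

As far as these compounds go, what stays open is whether hydroxy to methoxy moves the number at all on the core shared by compound 3 and compound 4, set against a 39-fold higher number from compound 1 to compound 2 (1.59 log units; beyond the scatter) on the other core.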